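Chloro in place of methyl on the shared core

The source may report more compounds than this note shows. Statements on the series, on what has been measured and on what is new or still open speak of the compounds shown alone.

Compound 1 `COc1ccc(/C=C/C(=O)/C=C/c2nc3cc(C)ccc3n2C)cc1O` gives 7700 nM
Compound 2 `COc1ccc(/C=C/C(=O)/C=C/c2nc3c(C)c(C)ccc3n2C)cc1O` gives 7300 nM

Among the measured compounds shown here, in a functional assay on NCI-H460 cells (Homo sapiens) for cytotoxicity, read by MTT assay, with a stated time of 48 h (on this read-out lower numbers stand for stronger inhibition and higher numbers for weaker inhibition), compound 1 stands level with compound 2 within the scatter, and these are the only two numbers so far. Compound 3 `COc1ccc(/C=C/C(=O)/C=C/c2nc3cc(Cl)ccc3n2C)cc1O` differs from compound 1 by chloro in place of methyl on an aromatic carbon with chloro in place of methyl on an aromatic carbon. For the measured compounds named here, the one measured step that bears on this is a 1.1-fold lower number from compound 1 to compound 2 (0.02 log units; within the scatter) for methyl in place of hydrogen on an aromatic carbon. Going by the values given here, no chloro compound has been measured, so this guide is indirect. No step beyond the scatter is expected, in either direction. For compound 3 the expected value is 7000 nM (estimated range 3500 nM to 14000 nM).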

Compound 3, half-maximal inhibitory concentration: 7300 nM
The estimate for compound 3 lay 1.0-fold (0.02 log units) below the measured number, and the stated range covers the measured number.
By their numbers in this assay, from the lowest: compounds 2, 3 and 1 (each within the scatter of the next).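

In this assay, chloro in place of methyl on an aromatic carbon gives a 1.1-fold lower number from compound 1 to compound 3 (0.02 log units; within the scatter). At this position, meta to a fused ring and para to a fused ring, the methyl can thus be replaced by chloro with the number staying level, whereas the earlier step covered only methyl in place of hydrogen. No evidence on hand accounts for this result.

Going by these compounds, whether an amine or a carboxylic acid at this position would move the number beyond the scatter remains open. So does whether chloro in place of methyl reads the same on the core of compound 2.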